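Swapping methyl for benzyl on a weak inhibitor

The compounds below may be only part of what the source reports. "The series", "measured", "known", "first", "only" and "open" are said of these compounds alone.

- compound 1 `C=C1CC[C@H]2[C@@](C)(CC[C@@H](OC(C)=O)[C@@]2(C)C(=O)OCc2ccccc2)[C@@H]1CCC1=CCOC1=O`: 12900 nM
- compound 2 `C=C1CC[C@H]2[C@@](C)(CC[C@@H](OC(C)=O)[C@@]2(C)C(=O)OCc2ccccc2)[C@@H]1/C=C/C1=CCOC1=O`: 52700 nM
- compound 3 `C=C1CC[C@H]2[C@@](C)(CC[C@@H](OC(C)=O)[C@@]2(C)C(=O)OC)[C@@H]1C/C=C1\C=COC1=O`: 69700 nM

In a functional assay on NIH3T3 cells (Mus musculus) for inhibition, read by MTT assay, with a stated time of 72 h (a higher number here means a weaker inhibitor, a lower number a stronger inhibitor), compound 3 gives 69700 nM, which lies within the usual scatter of compound 2 and marks a clearly weaker inhibitor than compound 1. The structural change leading to compound 4 `C=C1CC[C@H]2[C@@](C)(CC[C@@H](OC(C)=O)[C@@]2(C)C(=O)OCc2ccccc2)[C@@H]1C/C=C1\C=COC1=O` is phenyl in place of hydrogen on a saturated chain carbon bound to an oxygen next to a carbonyl group. Put simply, methoxycarbonyl becomes benzyloxycarbonyl.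

For the measured compounds named here, the only measured step, a 4.1-fold higher number from compound 1 to compound 2 (0.61 log units; beyond the scatter), is modest, but it keeps benzyloxycarbonyl and alters a different group. No measurement therefore tests this swap directly. The indirect evidence is mixed, since both compounds that carry benzyloxycarbonyl can be compared with compound 3. Compound 1, at 12900 nM, points to a stronger inhibitor, while compound 2, at 52700 nM, shows no separation from compound 3 beyond the scatter.

A modest move toward a stronger inhibitor in this assay is expected, though no real change remains possible, and the expected step is a 2.3-fold lower number from compound 3 to compound 4 (0.37 log units; beyond the scatter). The estimate for compound 4 is 30000 nM, with an expected range of 10000 nM to 80000 nM.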

Compound 4, half-maximal inhibitory concentration: 78000 nM
Compound 4: middle estimate off by 2.6-fold (0.41 log units), on the low side; measured number inside the range.
By their numbers in this assay, from the lowest: compound 1; then compounds 2, 3 and 4 (each within the scatter of the next).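

In this assay, the direct test of this swap gives a 1.1-fold higher number from compound 3 to compound 4 (0.05 log units; within the scatter), so exchanging methoxycarbonyl for benzyloxycarbonyl, with phenyl in place of hydrogen on a saturated chain carbon bound to an oxygen next to a carbonyl group, produces no real change in this compound pair. Two further steps give a 1.5-fold higher number from compound 2 to compound 4 (0.17 log units; within the scatter) and a 6.0-fold higher number from compound 1 to compound 4 (0.78 log units; beyond the scatter), so among these steps only the one with the different five-membered-ring group of compound 1 lies beyond the scatter. Nothing available explains why the added phenyl leaves the number unchanged.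

Going by these compounds, it remains open whether the same swap would also change nothing when paired with the group carried by compound 1. Also open, on these data alone, is how a carboxylic acid, an amide or a longer chain in place of benzyloxycarbonyl would read in this assay.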